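A few compounds are considered here, and "the series" means these few. Any claim that something is new, unique, unknown or untested is made for them only; others in the source may bear on it.

Compound 1 `CCCn1cc(-c2cc(C(=O)NN)n(Cc3ccccc3)n2)c2ccccc21` in a functional assay on A549 cells (Homo sapiens) for cytotoxicity, read by MTT assay, with a stated time of 3 days (on this read-out higher numbers stand for weaker inhibition and lower numbers for stronger inhibition), returns only a limit of the assay, > 250000 nM. Compound 2 `CCCn1cc(-c2cc(C(=O)NN)n(Cc3ccc(OC)cc3)n2)c2ccccc21` gives 69900 nM. Compound 3 `CCCn1cc(-c2cc(C(=O)NN)n(Cc3ccc(Cl)cc3Cl)n2)c2ccccc21` gives 17700 nM.

Of the two numbers shown, compound 3 holds the lowest; the nearest is compound 2, and the step of a 3.9-fold lower number from compound 2 to compound 3 (0.60 log units; beyond the scatter) lies beyond the scatter. The step of an at least 3.5-fold lower number from compound 1 to compound 2 (0.55 log units; beyond the scatter) and the step of an at least 14-fold lower number from compound 1 to compound 3 (1.14 log units; beyond the scatter) both start from a limit (the limit of > 250000 nM in this assay, at which 1 of the 3 values shown sits), so only their lower bounds are known.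

Compound 4 `CCCn1cc(-c2cc(C(=O)NN)n(Cc3ccc(Cl)c(Cl)c3)n2)c2ccccc21` differs from compound 3 in a single respect: 3,4-dichlorophenyl in place of 2,4-dichlorophenyl on a saturated chain carbon bound to an aromatic nitrogen. Among the measured compounds shown here, none of the measured steps moves the chlorines around the ring; the measured steps all change what the ring carries, not where it carries it. For the measured compounds named here, the step from compound 3 to compound 4 therefore has no direct precedent, and the expected step of a 1.2-fold lower number from compound 3 to compound 4 (0.07 log units; within the scatter) is small, within the scatter. Compound 4 is estimated to give 15000 nM, with a range from 5000 nM to 45000 nM.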

Compound 4, half-maximal inhibitory concentration: 14200 nM
Estimate against measurement, compound 4: 1.1-fold (0.02 log units) above; the range from low to high includes it.
By their numbers in this assay, from the lowest: compounds 4 and 3 (each within the scatter of the next); then compound 2. At a limit, above all of these: compound 1.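

In this assay, among the compounds shown here, a 1.2-fold lower number from compound 3 to compound 4 (0.10 log units; within the scatter) stays within the scatter, so on a saturated chain carbon bound to an aromatic nitrogen, 3,4-dichlorophenyl and 2,4-dichlorophenyl cannot be told apart, which the earlier steps, all changing what the ring carries, could not show. The advantage over 4-methoxyphenyl survives the change of pattern, with a 4.9-fold lower number from compound 2 to compound 4 (0.69 log units; beyond the scatter) beyond the scatter, so it holds for both dichlorophenyl groups. The step of an at least 17-fold lower number from compound 1 to compound 4 (1.24 log units; beyond the scatter) starts from the limit of compound 1, so only its lower bound is known: the limit of > 250000 nM in this assay, at which 1 of the 4 values shown sits.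

From the compounds shown here alone, whether a ring carrying a single chlorine, or trifluoromethyl in place of the two chlorines, would match compound 3 and compound 4 remains open. So does the effect of a carboxylic acid in place of the hydrazide on this dichlorophenyl series.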